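Changing one aromatic group on a shared core

This account rests on a few compounds, and the source may have more. Where it says the series, first, only, none or still open, it means among the compounds named here.

Measured so far in a functional assay on MDA-MB-231 cells (Homo sapiens) for antiproliferative activity, read by MTT assay, with a stated time of 48 h; on this read-out higher numbers stand for weaker inhibition and lower numbers for stronger inhibition 
- compound 1 `C=CS(=O)(=O)N1CCN(c2ncnc3sc(-c4cccc5ncccc45)cc23)CC1` gives 21000 nM 
- compound 2 `C=CS(=O)(=O)N1CCN(c2ncnc3sc(-c4ccc(F)nc4)cc23)CC1` gives 16000 nM 

Compound 2 at 16000 nM stands level with compound 1 at 21000 nM, as the two values lie within the scatter of each other. The next compound, compound 3 `C=CS(=O)(=O)N1CCN(c2ncnc3sc(-c4cn(C)nc4C(F)(F)F)cc23)CC1`, keeps the shared core and differs from compound 2 in one place. The change is 1-methyl-3-(trifluoromethyl)-1H-pyrazol-4-yl in place of 6-fluoropyridin-3-yl on an aromatic carbon, on an aromatic carbon of a five-membered aromatic ring with 1 sulfur, next to the ring sulfur.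

For the measured compounds named here, only one measured step bears on this, and it concerns the same place: a 1.3-fold lower number from compound 1 to compound 2 (0.12 log units; within the scatter). That exchange of one aromatic group for another produced no difference beyond the scatter. Going by the values given here, no measured compound carries a pyrazole ring or a trifluoromethyl group, so this single step is a thin guide. No clear shift in either direction is therefore expected in this assay. The estimated change is a 1.1-fold higher number from compound 2 to compound 3 (0.05 log units; within the scatter) and would not be a real difference. Compound 3 is expected near 18000 nM, with an estimated range from 7000 nM to 45000 nM as its likely span.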

Compound 3, half-maximal inhibitory concentration: 10400 nM
For compound 3 the middle estimate is 1.7-fold (0.24 log units) above the measured one, within the range that was stated.
By their numbers in this assay, from the lowest: compounds 3, 2 and 1 (each within the scatter of the next, the first and the last beyond it).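

In this assay, the exchange of 6-fluoropyridin-3-yl for 1-methyl-3-(trifluoromethyl)-1H-pyrazol-4-yl gives a 1.5-fold lower number from compound 2 to compound 3 (0.19 log units; within the scatter), so this pair stands level, whereas the exchange of quinolin-5-yl for the same pyrazole group gives a 2.0-fold lower number from compound 1 to compound 3 (0.31 log units; beyond the scatter), a modest step and the first at this position to pass beyond the scatter. The group on this aromatic carbon, next to the ring sulfur, can therefore shift the number to a small degree, and a five-membered aromatic ring with 2 hetero atoms can stand here in place of the six-membered ring of compound 2 with no difference beyond the scatter. No measurement at hand explains the shift from compound 1 to compound 3.

The pyrazole ring, its methyl group and its trifluoromethyl group all enter together, so the compounds shown cannot tell which of these parts matters. Going by these compounds, it also remains open whether a simple pyrazole without the trifluoromethyl group, or a ring carrying an amine or a carboxylic acid at this place, would move the number further in either direction.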